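Bromo to methyl on the ketone aryl ring of compound 3

A few compounds are considered here, and "the series" means these few. Any claim that something is new, unique, unknown or untested is made for them only; others in the source may bear on it.

Three measured compounds share one core and differ only in the group on the phenyl ring of the ketone. Compound 1 `COc1cc(-c2nnc(SCC(=O)c3ccccc3)n2N)cc(OC)c1OC` carries no substituent there, and in a functional assay on HepG2 cells (Homo sapiens) for antiproliferative activity, read by MTT assay, with a stated time of 48 h (a higher number here means a weaker inhibitor, a lower number a stronger inhibitor), compound 1 gives 7800 nM. Compound 2 `COc1cc(-c2nnc(SCC(=O)c3ccc(Cl)cc3)n2N)cc(OC)c1OC` bears chloro on that ring. In this assay compound 2 reaches > 100000 nM, which is a limit of the assay and not a number. Compound 3 `COc1cc(-c2nnc(SCC(=O)c3ccc(Br)cc3)n2N)cc(OC)c1OC` bears bromo, and in this assay compound 3 gives 92500 nM. Of the two numbers shown, compound 3 stands highest, with compound 1 the nearest. The step of a 12-fold higher number from compound 1 to compound 3 (1.07 log units; beyond the scatter) is large, as is an at least 12-fold higher number from compound 1 to compound 2 (1.10 log units; beyond the scatter), while an at least 1.0-fold lower number from compound 2 to compound 3 (0.03 log units; that floor lies within the scatter) stays within the scatter.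

Compound 4 `COc1cc(-c2nnc(SCC(=O)c3ccc(C)cc3)n2N)cc(OC)c1OC` differs from compound 3 in one place: methyl in place of bromo on an aromatic carbon. Among the measured compounds shown here, no measured step exchanges a halogen for methyl, so the measured steps bear on it only indirectly: both halogens at this place moved the number well upward from the unsubstituted compound 1, and the two halogens did not differ. Whether methyl behaves like a halogen here is not shown. Compound 4 is therefore expected to give 40000 nM, within 10000 nM to 150000 nM. That estimate means an expected step of a 2.3-fold lower number from compound 3 to compound 4 (0.36 log units; beyond the scatter), a modest move downward.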

Compound 4, half-maximal inhibitory concentration: > 100000 nM
Compound 4 gave a limit, no number (the forecaster's own chance of this, stated with the estimate: 25%); at least 2.5-fold (0.39 log units) between middle value and limit.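

The upward move at this place is not confined to halogens: in this assay the record shows an at least 12-fold higher number from compound 1 to compound 4 (1.10 log units; beyond the scatter), a large step of the kind that chloro and bromo also gave. Exchanging bromo for methyl gives an at least 1.0-fold higher number from compound 3 to compound 4 (0.03 log units; that floor lies within the scatter), so this comparison does not separate 4-methylphenyl from 4-bromophenyl on the ketone. The result for compound 4 is a limit of the assay and not a number, the step between compound 2 and compound 4 cannot be read, and the high end of this small set is bounded by that limit: the limit of > 100000 nM in this assay, at which 2 of the 4 values shown sit.

Whether any substituent at this place keeps the number close to that of compound 1, at 7800 nM, remains open, since all three groups shown moved it well upward, and a fluoro, a hydroxyl, an amine or a carboxylic acid on the same carbon would test this directly. Also open, going by these compounds, are how far compound 2 and compound 4 lie past the limit and whether methyl would have the same outcome on another carbon of that ring.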